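Isopropyl for Cyclopropyl in Rat Reductase Inhibition

A few compounds are considered here, and "the series" means these few. Any claim that something is new, unique, unknown or untested is made for them only; others in the source may bear on it.

compound 1, `CC(C)c1nc2c(c(-c3ccccc3)nn2C)c(-c2ccc(F)cc2)c1/C=C/[C@@H](O)C[C@@H](O)CC(=O)O`: 37%
compound 2, `Cn1nc(-c2ccccc2)c2c(-c3ccc(F)cc3)c(/C=C/[C@@H](O)C[C@@H](O)CC(=O)O)c(C3CC3)nc21`: -54.4%
compound 3, `Cc1cc2nc(C3CC3)c(/C=C/[C@@H](O)C[C@@H](O)CC(=O)O)c(-c3ccc(F)cc3)n2n1`: -27.1%

These three values come from an in vivo functional assay on the whole organism for inhibition of 3-hydroxy-3-methylglutaryl-coenzyme A reductase (Rattus norvegicus), at a dose of 0.2 mg/kg by the oral route; on this read-out higher numbers stand for a stronger effect at the one dose given and lower numbers for a weaker effect. Compound 1 and compound 2 share one core and differ in one place: isopropyl in place of cyclopropyl on an aromatic carbon. This change made a number 91.4 percentage points higher from compound 2 to compound 1 (beyond the scatter). Compound 3 stands on a different core; how the core of compound 3 differs from that of compound 2 is not broken down here. In this assay compound 3 gives -27.1%, which lies between the values of the other two.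

Compound 4, `Cc1cc2nc(C(C)C)c(/C=C/[C@@H](O)C[C@@H](O)CC(=O)O)c(-c3ccc(F)cc3)n2n1`, has not been measured. It differs from compound 3 by the same kind of change as compound 1 from compound 2: isopropyl in place of cyclopropyl on an aromatic carbon. The surroundings are not identical, though: in compound 3 the ring carries 2 nitrogen, the place is ortho to a large group and opposite the ring nitrogen, whereas in compound 2 the ring carries 1 nitrogen and the place is ortho to a 6-carboxy-3,5-dihydroxyhex-1-en-1-yl group.

Because a number 91.4 percentage points higher from compound 2 to compound 1 (beyond the scatter) shows this change acting strongly on the other core, a rise is expected for compound 4 as well. The expected step, a number 52.1 percentage points higher from compound 3 to compound 4 (beyond the scatter), is set smaller than that earlier one, since it rests on a single pair on a different core. Compound 4 is therefore estimated at 25%, with a range from -20% to 60%.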

Compound 4, a percentage reported as inhibition, in the whole organism at one dose (the size of the read-out at that dose, not a potency): -6.1%
Compound 4: middle estimate off by 31.1 percentage points, on the high side; measured number inside the range.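

In this assay, isopropyl in place of cyclopropyl on an aromatic carbon gave a number 21 percentage points higher from compound 3 to compound 4 (beyond the scatter) on the second core, so the direction of the change held in both pairs shown. Its size did not carry over, and the two steps differ by more than their scatter allows: the same change on two cores in this assay, a number 91.4 percentage points higher (beyond the scatter) from compound 2 to compound 1 and a number 21 percentage points higher (beyond the scatter) from compound 3 to compound 4, 70.4 percentage points apart, beyond the scatter of two such steps. This shows that a step measured on one core in this series could be relied on for its sign here but not for its size, yet two pairs cannot establish a rule, and they do not show what sets the size of the step on either core.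

The compounds shown leave open whether other groups on the same aromatic carbon, such as ethyl, tert-butyl or a longer chain like n-butyl, would continue the rise seen with isopropyl on both cores or would behave differently on each. They also leave open whether the gap between the two steps would persist at other oral doses, as each step rests on a single dose in the whole organism and gives no potency.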